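This account rests on a few compounds, and the source may have more. Where it says the series, first, only, none or still open, it means among the compounds named here.

Measured compounds:
- compound 1 `O=C(O)c1ccccc1NC(=O)C(C1CCCCC1)n1c(-c2ccc(Cl)cc2)nc2cc(F)c(F)cc21`: > 40000 nM
- compound 2 `O=C(O)CO[C@H]1CC[C@H](NC(=O)[C@H](C2CCCCC2)n2c(-c3ccc(Cl)nc3)nc3cc(F)c(F)cc32)CC1`: 9900 nM

Both compounds were tested in a functional assay for agonist activity at Bile acid receptor (Homo sapiens), read by a luciferase reporter; on this read-out higher numbers stand for an effect only at larger amounts of compound and lower numbers for an effect already at smaller amounts. For compound 1 the value > 40000 nM is only a limit of the assay, not a number: the compound showed no effect up to the largest amount tested. Compound 2, which carries a different acid-bearing group on the amide nitrogen, gives a number in this assay, 9900 nM. Going by the values given here, no step between two measured compounds that differ in a single place is available here; the only marked point is the limit of > 40000 nM in this assay, at which 1 of the 2 values shown sits.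

Compound 3 `O=C(O)c1ccc(NC(=O)C(C2CCCCC2)n2c(-c3ccc(Cl)cc3)nc3cc(F)c(F)cc32)nc1` is not yet measured. It differs from compound 1 in one place: 5-carboxypyridin-2-yl in place of 2-carboxyphenyl on an amide-type nitrogen. With compound 1 standing only at a limit, the direction of the step from compound 1 to compound 3 cannot be read from data; the expectation is a step of roughly an at least 1.3-fold lower number from compound 1 to compound 3 (0.12 log units; that floor lies within the scatter), possibly none beyond the scatter. For compound 3 the estimated value in this assay is 30000 nM, expected to lie between 5000 nM and 100000 nM.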

Compound 3, half-maximal effective concentration: 10600 nM
For compound 3 the middle estimate is 2.8-fold (0.45 log units) above the measured one, within the range that was stated.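

The acid-bearing group on the amide-type nitrogen matters to this read-out: placing 5-carboxypyridin-2-yl there instead of 2-carboxyphenyl gives an at least 3.7-fold lower number from compound 1 to compound 3 (0.57 log units; beyond the scatter) in this assay. With the shared core unchanged, this single swap yields a measurable effect for compound 3. The true size of the step remains unknown and the printed figure is only a minimum, because the value for compound 1 is a limit of the assay rather than a number: the limit of > 40000 nM in this assay, at which 1 of the 3 values shown sits.

This swap changes both the ring, which gains a nitrogen, and the place of the carboxy group on it, so the compounds shown cannot tell which of the two changes matters. From the compounds shown here alone, it also remains open whether the carboxylic acid itself is needed, or whether a tetrazole or a primary amide on the same ring would serve in its place.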